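From compound 3 to compound 4: working notes

A few compounds are considered here, and "the series" means these few. Any claim that something is new, unique, unknown or untested is made for them only; others in the source may bear on it.

Compound 1 `O=C1c2c[n+]([O-])c3ccccc3c2C(=O)c2c1c1ccccc1n2CCCCN1CCCCC1`: 190 nM
Compound 2 `O=C1c2c[n+]([O-])c3ccccc3c2C(=O)c2c1c1ccccc1n2CCN1CCCCC1`: 180 nM
Compound 3 `CN1CCN(CCCCCn2c3c(c4ccccc42)C(=O)c2c[n+]([O-])c4ccccc4c2C3=O)CC1`: 1710 nM

All values come from a functional assay on A-375 cells (Homo sapiens) for cytotoxicity, read by MTT assay, with a stated time of 72 h; on this read-out lower numbers stand for stronger inhibition and higher numbers for weaker inhibition. Compound 3 stands highest of the three, and both of its steps lie beyond the scatter: a 9.0-fold higher number from compound 1 to compound 3 (0.95 log units; beyond the scatter), and a 9.5-fold higher number from compound 2 to compound 3 (0.98 log units; beyond the scatter).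

The next entry is compound 4 `O=C1c2c[n+]([O-])c3ccccc3c2C(=O)c2c1c1ccccc1n2CCCN1CCC(O)CC1`. The change is 4-hydroxypiperidin-1-yl in place of 2-(4-methylpiperazin-1-yl)ethyl on a saturated chain carbon, three bonds along the chain from an aromatic nitrogen. Cut further out, 5-(4-methylpiperazin-1-yl)pentyl gives way to 3-(4-hydroxypiperidin-1-yl)propyl.

Among the measured compounds shown here, three measured steps bear on this. The step of a 1.1-fold lower number from compound 1 to compound 2 (0.02 log units; within the scatter) lies within the scatter, so the difference between the side chains of these two compounds leaves no measurable trace here. The two modest steps to compound 3 change the ring and the chain together, and the data do not separate those two changes. For the measured compounds named here, compound 4 has a piperidine-type ring like compound 1 and compound 2, but no measured compound carries 4-hydroxypiperidin-1-yl, so the full return to their level is not assumed. A move to a lower number is expected, probably somewhat smaller than those two steps. The expected step is a 3.8-fold lower number from compound 3 to compound 4 (0.58 log units; beyond the scatter). For compound 4 the estimated value is 450 nM, with an expected range of 150 nM to 1300 nM.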

Compound 4, half-maximal inhibitory concentration: 240 nM
Beside the measured number, compound 4's estimate is 1.9-fold (0.27 log units) above it, and the stated range covers the measured number.
By their numbers in this assay, from the lowest: compounds 2, 1 and 4 (each within the scatter of the next); then compound 3.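

Working notes on the side chain, read in this assay: a 4-hydroxypiperidin-1-yl ring at the chain end stays level with the unsubstituted piperidin-1-yl ring, with a 1.3-fold higher number from compound 2 to compound 4 (0.12 log units; within the scatter) and a 1.3-fold higher number from compound 1 to compound 4 (0.10 log units; within the scatter), even though chain length differs in both pairs. The step of a 7.1-fold lower number from compound 3 to compound 4 (0.85 log units; beyond the scatter) adds a third chain length with a piperidine-type ring, and compound 3, with its 4-methylpiperazin-1-yl ring on a pentyl chain, is now the only one of the four set apart from the rest. Nothing available on these compounds gives a reason for this pattern.

Ring and chain still change together in every step to compound 3, so a 4-methylpiperazin-1-yl ring on a propyl chain, or a piperidin-1-yl ring on a pentyl chain, would be needed to tell which of the two goes with the higher number. As far as these compounds go, whether a morpholin-4-yl ring or an open dimethylamino group at the chain end would stay at the level of the piperidine-type rings also remains open.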